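The source may hold more compounds than are shown below. What is called first, only, known or untested is meant among the compounds shown, and "the series" means these compounds.

Going by the values given here, in a functional assay on CHO cells for positive allosteric modulation of metabotropic glutamate receptor 2 (Homo sapiens), read by GTPgammaS binding, with a stated time of 30 min (a higher number here means a larger maximal response, a lower number a smaller maximal response), compound 2 `Clc1c(N2CCC(c3ccccc3)CC2)ccn2c(CC3CC3)nnc12` gives 343%, the highest of the two numbers known so far, while compound 1 `FC(F)(F)Cc1nnc2c(Cl)c(N3CCC(c4ccccc4)CC3)ccn12` gives 300%. Compound 3 `CCc1nnc2c(Cl)c(N3CCC(c4ccccc4)CC3)ccn12` remains to be measured in this assay. It differs from compound 2 by methyl in place of cyclopropyl on a saturated chain carbon bound to an aromatic carbon. Among the compounds with values here, the only measured step on that same saturated chain carbon was a number 43 percentage points higher from compound 1 to compound 2 (beyond the scatter), a large shift for a small alteration, so a further change of similar size cannot be excluded, though its direction is uncertain. Compound 3 is therefore expected to give about 310%, within 250% to 370%, which would be a step of a number 33 percentage points lower from compound 2 to compound 3 (beyond the scatter).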

Compound 3, largest response reached (Emax), in percent of the reference or control that the assay uses: 262%
Compound 3: middle estimate off by 48 percentage points, on the high side, and the stated range covers the measured number.
By their numbers in this assay, from the lowest: compound 3; then compound 1; then compound 2.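

In this assay, methyl in place of cyclopropyl on this saturated chain carbon means a number 81 percentage points lower from compound 2 to compound 3 (beyond the scatter), and methyl in place of trifluoromethyl means a number 38 percentage points lower from compound 1 to compound 3 (beyond the scatter). The earlier pair showed only that the response shifts at this position; now both groups are seen to give a larger maximal response than methyl, and compound 3 stands lowest of the three. Nothing available explains these differences. As far as these compounds go, whether a longer chain such as propyl, or an amine, on this carbon would raise or lower the response remains open.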